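Compound 4: piperidin-1-yl on the carbonyl carbon

The compounds below may be only part of what the source reports. "The series", "measured", "known", "first", "only" and "open" are said of these compounds alone.

Of the compounds shown here, three with a shared core have been measured in a functional assay on 143B cells (Homo sapiens) for inhibition, read by MTT assay, with a stated time of 72 h; a lower number here means a stronger inhibitor, a higher number a weaker inhibitor. Compound 1 `COc1ccccc1NC(=O)CCC(=O)OCCCCCCSc1ccc([N+](=O)[O-])c2nonc12`, with 2-methoxyphenyl on the amide-type nitrogen, gives 2120 nM. Compound 2 `O=C(CCC(=O)OCCCCCCSc1ccc([N+](=O)[O-])c2nonc12)Nc1ccc(F)cc1`, with 4-fluorophenyl there, gives 2500 nM. Compound 3 `O=C(CCC(=O)OCCCCCCSc1ccc([N+](=O)[O-])c2nonc12)Nc1ccc(C(F)(F)F)cc1`, with 4-(trifluoromethyl)phenyl, gives 2100 nM, which places it level with the other two.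

Compound 4 `O=C(CCC(=O)N1CCCCC1)OCCCCCCSc1ccc([N+](=O)[O-])c2nonc12` has not yet been measured. It changes the group on a carbonyl carbon: piperidin-1-yl in place of (4-(trifluoromethyl)phenyl)amino on a carbonyl carbon. In words, piperidin-1-yl stands in place of (4-(trifluoromethyl)phenyl)amino.

Within the data shown here, the only steps that bear on this are exchanges of one aromatic group for another on that nitrogen. They are a 1.2-fold higher number from compound 1 to compound 2 (0.07 log units; within the scatter), a 1.0-fold lower number from compound 1 to compound 3 (0.00 log units; within the scatter) and a 1.2-fold lower number from compound 2 to compound 3 (0.08 log units; within the scatter), all within the scatter. None of them removes the aromatic ring or the amide hydrogen, so the change in compound 4 goes beyond anything tested so far. Still, the three compounds show no sensitivity to what was varied at this end, and nothing in the data points to a direction.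

No step beyond the scatter is therefore expected in this assay, and the expected step is a 1.2-fold higher number from compound 3 to compound 4 (0.08 log units; within the scatter). Compound 4 is estimated at 2500 nM, with an expected range of 1000 nM to 6000 nM.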

Compound 4, half-maximal inhibitory concentration: 1900 nM
The estimate for compound 4 lay 1.3-fold (0.12 log units) above the measured number, within the range that was stated.
By their numbers in this assay, from the lowest: compounds 4, 3, 1 and 2 (each within the scatter of the next).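

In this assay, piperidin-1-yl on the carbonyl carbon takes away both the aromatic ring and the amide hydrogen, yet the number stays within the scatter of all three earlier compounds (a 1.1-fold lower number from compound 3 to compound 4 (0.04 log units; within the scatter); a 1.3-fold lower number from compound 2 to compound 4 (0.12 log units; within the scatter); a 1.1-fold lower number from compound 1 to compound 4 (0.05 log units; within the scatter)). Among these compounds, the earlier compounds showed only that one aromatic group could stand in for another on the amide-type nitrogen, whereas compound 4 shows that, for this replacement, neither the aromatic ring nor the amide hydrogen is needed to keep the number at this level, and that a group with fewer heavy atoms serves as well. Nothing at hand explains why this end of the molecule makes so little difference.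

As far as these compounds go, whether this holds for every group at this carbonyl carbon stays open, since an open-chain amine such as diethylamino or a free carboxylic acid could still behave differently. From the compounds shown here alone, all four compounds also share the same chain and core, so what a longer chain or a change in the shared core would do in this assay remains unknown.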